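Leaving the (piperidin-1-yl)carbonyl group behind

The source may hold more compounds than are shown below. What is called first, only, known or untested is meant among the compounds shown, and "the series" means these compounds.

Compound 1 `CNC(=N)Nc1nc(-c2ccc(OC)cc2)c(-c2ccc(OC)cc2)s1` gives 62 nM
Compound 2 `COc1ccc(-c2nc(CN)sc2-c2ccc(OC)cc2)cc1` gives > 100 nM (a limit)
Compound 3 `COc1ccc(-c2nc(C(=O)N3CCCCC3)sc2-c2ccc(OC)cc2)cc1` gives > 1000 nM (a limit)

In a functional assay with Oryctolagus cuniculus as the target (on this read-out higher numbers stand for weaker inhibition and lower numbers for stronger inhibition), compound 3 stands at > 1000 nM as a limit and not a number. Compound 4 `CCOC(=O)/C=C/c1nc(-c2ccc(OC)cc2)c(-c2ccc(OC)cc2)s1` differs from compound 3 by 2-(ethoxycarbonyl)ethenyl in place of (piperidin-1-yl)carbonyl on an aromatic carbon and keeps both 4-methoxyphenyl groups. Bearing on this are an at least 16-fold higher number from compound 1 to compound 3 (1.20 log units; beyond the scatter) as the one large step and an at least 1.6-fold higher number from compound 1 to compound 2 (0.20 log units; that floor lies within the scatter) with only a floor and a step that the two limits leave unreadable from compound 2 to compound 3 which stays open. Compound 1 alone gives a number. With an at least 16-fold higher number from compound 1 to compound 3 (1.20 log units; beyond the scatter) as the guide, compound 4 is expected to remain weak in this assay with no step beyond the scatter in either direction. The expected step is a number no higher from compound 3 to compound 4 (the limit leaves the size open) as an estimate against a limit. The expected value for compound 4 is 1000 nM with an estimated range from 150 nM to 5000 nM for now.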

Compound 4, half-maximal inhibitory concentration: 20 nM
Compound 4: the middle estimate sits 50-fold (1.70 log units) above what was measured; the whole stated range lies above it.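

In this assay, 2-(ethoxycarbonyl)ethenyl on this aromatic carbon gives the lowest number of the four compounds, with every step beyond the scatter. Within the data shown here, the one step between two real numbers is a 3.1-fold lower number from compound 1 to compound 4 (0.49 log units; beyond the scatter), so the group of compound 1 is not required for activity at this position. Compounds 2 and 3 stand only at limits, which makes the other two steps floors: an at least 50-fold lower number from compound 3 to compound 4 (1.69 log units; beyond the scatter) and an at least 5.0-fold lower number from compound 2 to compound 4 (0.69 log units; beyond the scatter).

The compounds shown do not separate the contribution of the ethenyl link from that of the ethyl ester. The saturated ethyl-linked ester and the free carboxylic acid would address those two parts.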